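Amide aryl exchange on two cores: outlook for compound 4

A few compounds are considered here, and "the series" means these few. Any claim that something is new, unique, unknown or untested is made for them only; others in the source may bear on it.

Measured in a functional assay on WM 266-4 cells (Homo sapiens) for antiproliferative activity, read by MTT assay, with a stated time of 24 h; on this read-out lower numbers stand for stronger inhibition of growth and higher numbers for weaker inhibition of growth:
compound 1 `COc1ccc(C2=NN(C(=O)c3ccc(Cl)nc3)C(c3ccc(OC)cc3)C2)cc1` gives 6450 nM
compound 2 `COc1ccc(C2=NN(C(=O)c3ccc(C)nc3Cl)C(c3ccc(OC)cc3)C2)cc1` gives 5740 nM
compound 3 `O=C(c1ccc(Cl)nc1)N1N=C(c2ccc(Cl)cc2)CC1c1ccc(OCc2ccccc2)cc1` gives 13200 nM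

Compound 3 carries the highest number of the three, beyond the scatter from both others; how its core differs from the core of compound 1 is not broken down here. From compound 1 to compound 2 the change is 2-chloro-6-methylpyridin-3-yl in place of 6-chloropyridin-3-yl on a carbonyl carbon, and it made a 1.1-fold lower number from compound 1 to compound 2 (0.05 log units; within the scatter). Compound 4 `Cc1ccc(C(=O)N2N=C(c3ccc(Cl)cc3)CC2c2ccc(OCc3ccccc3)cc2)c(Cl)n1` is not yet measured. It relates to compound 3 as compound 2 relates to compound 1, the change being (2-chloro-6-methylpyridin-3-yl in place of 6-chloropyridin-3-yl on a carbonyl carbon). In this assay the step from compound 3 to compound 4 is expected to be small, a 1.1-fold lower number from compound 3 to compound 4 (0.04 log units; within the scatter), because the same change gave a 1.1-fold lower number from compound 1 to compound 2 (0.05 log units; within the scatter). Compound 4 is therefore estimated at 12000 nM, with a range from 6000 nM to 25000 nM.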

Compound 4, concentration for 50% growth inhibition: 11400 nM
For compound 4 the middle estimate is 1.1-fold (0.02 log units) above the measured one; the measured number falls inside the stated range.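

In this assay, exchanging 6-chloropyridin-3-yl for 2-chloro-6-methylpyridin-3-yl on a carbonyl carbon gave a 1.2-fold lower number from compound 3 to compound 4 (0.06 log units; within the scatter). The exchange carries over between the two cores shown, with steps that agree: the same change on two cores in this assay, a 1.1-fold lower number (0.05 log units; within the scatter) from compound 1 to compound 2 and a 1.2-fold lower number (0.06 log units; within the scatter) from compound 3 to compound 4, 1.0-fold (0.01 log units) apart, within the scatter of two such steps

Going by these compounds alone, this shows only that the exchange leaves the number within the scatter on these two cores; it does not show the same on other cores or in other assays, and neither step gives the change a direction.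

Still open, on these data alone, is whether an acyl group of another kind on the ring amide nitrogen, such as a benzoyl carrying a carboxylic acid or an amine, would shift the number. Also open, as far as these compounds go, is what a single exchange on the core would do, such as a morpholine in place of the benzyloxy group of compound 3.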